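The source may hold more compounds than are shown below. What is called first, only, known or untested is meant among the compounds shown, and "the series" means these compounds.

Three compounds built on one shared core were tested in an assay on CHO cells for displacement of a labelled ligand from adenosine receptor A3 (Homo sapiens), read by scintillation counting, with a stated time of 120 min, tested at 10 uM; on this read-out lower numbers stand for less inhibition and higher numbers for more inhibition at the one concentration tested (going by the name of the read-out). Compound 1 `Nc1scc(CN2CCN(c3ccc(F)cc3Cl)CC2)c1C(=O)c1ccc(Cl)cc1` gives 0% in this assay. Compound 2 `Nc1scc(CN2CCN(c3ccccc3C(F)(F)F)CC2)c1C(=O)c1ccc(Cl)cc1` gives 0%, and compound 3 `Nc1scc(CN2CCN(c3ccc(Cl)c(C(F)(F)F)c3)CC2)c1C(=O)c1ccc(Cl)cc1` gives 3%. Compound 1 stands level with compound 2 at the digits shown; the step of no change at the digits printed from compound 1 to compound 2 (within the scatter) is within the scatter, as is the step of a number 3 percentage points higher from compound 1 to compound 3 (within the scatter) to the furthest of the three, and the step of a number 3 percentage points higher from compound 2 to compound 3 (within the scatter) between the other two. Among the measured compounds shown here, all three numbers therefore sit together near the bottom of the read-out, with no step among them that rises above the noise of repeated measurement.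

Compound 4 `Nc1scc(CN2CCN(c3ccc(OC(F)(F)F)cc3)CC2)c1C(=O)c1ccc(Cl)cc1` differs from compound 1 in one place: 4-(trifluoromethoxy)phenyl in place of 2-chloro-4-fluorophenyl on an amine nitrogen in a ring. Every measured step here also swaps the aryl group on an amine nitrogen in a ring while leaving the rest of the core unchanged, and each of those steps stayed within the scatter. The change to compound 4 is of the same kind, so no step beyond the scatter in this assay is expected, in either direction; the step expected is a number 2 percentage points higher from compound 1 to compound 4 (within the scatter). Compound 4 is estimated at 2%, with a range from -8% to 12%.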

Compound 4, a percentage reported as inhibition, at one concentration (the size of the read-out at that concentration, not a potency): 1%
The estimate for compound 4 lay 1 percentage points above the measured number, within the range that was stated.
By their numbers in this assay, from the lowest: compounds 1, 2, 4 and 3 (each within the scatter of the next).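

In this assay, among the compounds shown here, the earlier compounds carried only halogen or trifluoromethyl substituents on the aryl group, whereas the 4-(trifluoromethoxy)phenyl group brings an oxygen, a hydrogen-bond acceptor and more heavy atoms to the amine nitrogen in a ring, and the step is still only a number 1 percentage points higher from compound 1 to compound 4 (within the scatter). The comparisons with the other two aryl groups read the same way, with a number 1 percentage points higher from compound 2 to compound 4 (within the scatter) and a number 2 percentage points lower from compound 3 to compound 4 (within the scatter), so across these four compounds, adding an acceptor to the group at this position does not separate compound 4 from the others. No measurement offered here explains why the numbers stay together at this position.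

The compounds shown leave open whether an amine or a carboxylic acid on the aryl ring, or a longer chain in place of the aryl group, would move the number beyond the scatter. They also leave open what a change elsewhere on the shared core would do, such as replacing the 4-chlorophenyl group on the carbonyl with another group.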